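From Ethyl Ester to Thiazolyl Amide: An Expected Step

A few compounds are considered here, and "the series" means these few. Any claim that something is new, unique, unknown or untested is made for them only; others in the source may bear on it.

Measured in a functional assay on the whole organism for inhibition, with Rattus norvegicus as the target, read by paw edema, at a dose of 100 mg/kg by the oral route; on this read-out lower numbers stand for less inhibition and higher numbers for more inhibition at the one dose given (going by the name of the read-out):
Compound 1, `CCOC(=O)c1c(O)c2cccnc2n(-c2ccccc2)c1=O`: 23.5%
Compound 2, `O=C(Nc1cccnc1)c1c(O)c2cccnc2n(-c2ccccc2)c1=O`: 30.3%
Compound 3, `O=C(Nc1ccncc1)c1c(O)c2cccnc2n(-c2ccccc2)c1=O`: 34.9%

Compound 1 stands lowest of the three numbers. Its gap to compound 2 is a number 6.8 percentage points higher from compound 1 to compound 2 (within the scatter), and its gap to compound 3 is a number 11.4 percentage points higher from compound 1 to compound 3 (beyond the scatter).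

Compound 4 is `O=C(Nc1nccs1)c1c(O)c2cccnc2n(-c2ccccc2)c1=O`. It differs from compound 1 by (1,3-thiazol-2-yl)amino in place of ethoxy on a carbonyl carbon. The two measured steps that bear on this change are a number 6.8 percentage points higher from compound 1 to compound 2 (within the scatter) and a number 11.4 percentage points higher from compound 1 to compound 3 (beyond the scatter), since both likewise put an amide-linked aromatic ring in place of the ethoxy on the carbonyl carbon. Compound 4 is therefore expected to move by a number 8.5 percentage points higher from compound 1 to compound 4 (within the scatter), a modest rise. Compound 4 is estimated at 32%, with a range from 20% to 44%.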

Compound 4, a percentage reported as inhibition, in the whole organism at one dose (the size of the read-out at that dose, not a potency): 4.6%
Compound 4: the middle estimate sits 27.4 percentage points above what was measured; the measured number lies below the stated range.
By their numbers in this assay, from the lowest: compound 4; then compounds 1, 2 and 3 (each within the scatter of the next, the first and the last beyond it).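

In this assay, an amide on this carbonyl carbon does not by itself raise the number: (1,3-thiazol-2-yl)amino in place of ethoxy gives a number 18.9 percentage points lower from compound 1 to compound 4 (beyond the scatter) and so reverses the direction seen with the pyridinyl amides. The ring on the amide nitrogen matters, with 1,3-thiazol-2-yl in place of pyridin-3-yl giving a number 25.7 percentage points lower from compound 2 to compound 4 (beyond the scatter) and in place of pyridin-4-yl giving a number 30.3 percentage points lower from compound 3 to compound 4 (beyond the scatter) as the largest step in this set. Nothing available accounts for this drop.

Still open, from the compounds shown here alone, is whether a phenyl ring on the amide nitrogen would follow the pyridinyl amides or compound 4. A carboxylic acid in place of the ethoxy also remains an open case.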